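Moving the Pyridyl Nitrogen: What to Expect for Compound 3

A few compounds are considered here, and "the series" means these few. Any claim that something is new, unique, unknown or untested is made for them only; others in the source may bear on it.

Measured so far:
Compound 1, `Oc1ccc(-c2cc(-c3ccsc3)cc(-c3ccccc3O)n2)cc1`: in a functional assay on HCT-15 cells (Homo sapiens) for cytotoxicity, read by CCK-8 assay (on this read-out higher numbers stand for weaker inhibition and lower numbers for stronger inhibition), compound 1 reaches only the assay limit of > 50000 nM, not a number.
Compound 2, `Oc1ccc(-c2cc(-c3ccccn3)cc(-c3ccccc3O)n2)cc1`: in this assay compound 2 likewise reaches only the limit of > 50000 nM, not a number.

Both compounds share the same core and differ in a single aryl group. The step that the two limits leave unreadable from compound 1 to compound 2 cannot be sized: both of its ends sit at the limit. Compound 2 therefore stands at the limit of > 50000 nM in this assay, at which 2 of the 2 values shown sit, the same place as compound 1, with no number beneath it.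

Compound 3, `Oc1ccc(-c2cc(-c3cccnc3)cc(-c3ccccc3O)n2)cc1`, is not yet measured. It differs from compound 2 by pyridin-3-yl in place of pyridin-2-yl on an aromatic carbon. Within the data shown here, the only measured step, from a thiophen-3-yl to a pyridin-2-yl group, is unreadable in size and direction, so it offers no guide beyond showing that neither aryl group brought the value under the limit. For this assay compound 3 is expected to remain at the limit too, a step that the limit leaves unreadable from compound 2 to compound 3 that means no change beyond the scatter. The estimate for compound 3 is 60000 nM, with a range from 20000 nM to 200000 nM.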

Compound 3, half-maximal inhibitory concentration: > 50000 nM
Compound 3 was reported as a limit; the forecaster's own chance of this, stated with the estimate: 85%; the middle value is on the limit's open side.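

In this assay, among these compounds, no step among compound 1, compound 2 and compound 3 can be read, since each result is a limit and not a number: the limit of > 50000 nM in this assay, at which 3 of the 3 values shown sit. The compounds shown leave open whether pyridin-3-yl, pyridin-2-yl or thiophen-3-yl makes any difference to the shared core's effect on these cells.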